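Hydroxyethyl for Carbamoylethyl: Expected Tail Flick Activity

The source may report more compounds than this note shows. Statements on the series, on what has been measured and on what is new or still open speak of the compounds shown alone.

Three measured compounds share a common core. Compound 1 `C[C@H](NC(=O)CN(c1nc(Cl)nc2[nH]cnc12)C1CC1)C(=O)O` gives 43.5% in a functional assay on the whole organism (Tail, strain ICR) with Mus musculus as the target, in the tail flick test, with a stated time of 90 min, at a dose of 25 umol/kg by the oral route; a lower number here means a weaker effect, a higher number a stronger effect of the compound at the dose given. Compound 2 `NC(=O)CC[C@H](NC(=O)CN(c1ncnc2c1ncn2C1CCCCO1)C1CC1)C(=O)OCc1ccccc1` gives 37.8% in this assay, and compound 3 `NC(=O)C[C@H](NC(=O)CN(c1nc(Cl)nc2[nH]cnc12)C1CC1)C(=O)OCc1ccccc1` gives 32.3% in this assay. Compound 2 holds the second highest of the three numbers; its nearest neighbour is compound 3, within the scatter, and its furthest is compound 1, also within the scatter. Among the compounds with values here, no two measured compounds differ in only one place, so no single step is known. Compound 4 `C[C@@H](O)[C@H](NC(=O)CN(c1ncnc2c1ncn2C1CCCCO1)C1CC1)C(=O)OCc1ccccc1` is unmeasured and differs from compound 2 by 1-hydroxyethyl in place of 2-carbamoylethyl on a saturated chain carbon bound to an amide-type nitrogen and a carbonyl carbon. With compound 2 at 37.8% and compound 3 at 32.3% within the scatter, no step beyond the scatter is expected in this assay. Compound 4 is estimated at 36%, within 22% to 50%. The expected step is a number 1.8 percentage points lower from compound 2 to compound 4 (within the scatter).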

Compound 4, a percentage reported as activity, at one dose (the size of the read-out at that dose, not a potency): 23.4%
Compound 4: middle estimate off by 12.6 percentage points, on the high side; the measured number falls inside the stated range.
By their numbers in this assay, from the lowest: compounds 4, 3, 2 and 1 (each within the scatter of the next, the first and the last beyond it).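

In this assay, within the data shown here, the change from 2-carbamoylethyl to 1-hydroxyethyl gives a number 14.4 percentage points lower from compound 2 to compound 4 (beyond the scatter) and is the first single change whose effect can be read. It shows that the group at this place, on a saturated chain carbon bound to an amide-type nitrogen and a carbonyl carbon, can move the read-out beyond the scatter. Nothing given here accounts for this drop.

As far as these compounds go, whether a plain methyl, a carboxylic acid or an aminobutyl chain at this place would stand nearer compound 2 or compound 4 remains open. So does the part played by the defined stereocentre of 1-hydroxyethyl.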